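The source may hold more compounds than are shown below. What is called first, only, known or untested is meant among the compounds shown, and "the series" means these compounds.

Measured compounds and their values:
- compound 1, `Clc1cccc(-n2ncnc2Nc2ccccc2)c1Cl`: 363 nM
- compound 2, `Cc1ccccc1Nc1ncnn1-c1cccc(Cl)c1Cl`: 17.8 nM
- compound 3, `CCc1ccccc1Nc1ncnn1-c1cccc(Cl)c1Cl`: 45.7 nM

All three share one core and differ only in the group carried on the ring attached through the nitrogen. In a functional assay for antagonist activity at P2X purinoceptor 7 (Homo sapiens), read by FLIPR and calcium flux (a higher number here means a weaker inhibitor, a lower number a stronger inhibitor), compound 3 stands second highest of the three numbers. Its nearest neighbour is compound 2, the two being separated by a 2.6-fold higher number from compound 2 to compound 3 (0.41 log units; beyond the scatter); its furthest is compound 1, the gap there being a 7.9-fold lower number from compound 1 to compound 3 (0.90 log units; beyond the scatter).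

Compound 4, `COc1ccccc1Nc1ncnn1-c1cccc(Cl)c1Cl`, takes the next step: methoxy in place of ethyl on an aromatic carbon. Going by the values given here, two measured steps touch the same position. Adding a small group where compound 1 carries hydrogen gave a 20-fold lower number from compound 1 to compound 2 (1.31 log units; beyond the scatter), and adding a longer group gave a 7.9-fold lower number from compound 1 to compound 3 (0.90 log units; beyond the scatter), so a group of roughly this size at this spot has so far always given a much lower number than the bare hydrogen. Lengthening the group by one carbon, however, gave a 2.6-fold higher number from compound 2 to compound 3 (0.41 log units; beyond the scatter). Methoxy matches ethyl in heavy-atom count but brings an acceptor, for which no measured step exists. A modest move, in either direction or none beyond the scatter, is the reasonable expectation in this assay, with the lower-number side slightly favoured.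

Compound 4 is therefore expected to give about 30 nM, with a likely range from 10 nM to 90 nM. The expected step is a 1.5-fold lower number from compound 3 to compound 4 (0.18 log units; within the scatter).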

Compound 4, half-maximal inhibitory concentration: 102 nM
Beside the measured number, compound 4's estimate is 3.4-fold (0.53 log units) below it; measured number outside the range, above it.
By their numbers in this assay, from the lowest: compound 2; then compound 3; then compound 4; then compound 1.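

In this assay, exchanging ethyl for methoxy, two groups with the same heavy-atom count, gave a 2.2-fold higher number from compound 3 to compound 4 (0.35 log units; beyond the scatter), so at this position heavy-atom count alone does not set the number, and the change that brings in an oxygen and a hydrogen-bond acceptor goes with a weaker inhibitor. Set against methyl, methoxy gave a 5.7-fold higher number from compound 2 to compound 4 (0.76 log units; beyond the scatter), which leaves methyl with the lowest number of the groups shown, yet methoxy still holds a clear gain over bare hydrogen, with a 3.6-fold lower number from compound 1 to compound 4 (0.55 log units; beyond the scatter). No measurement at hand explains why the oxygen-bearing group falls behind the two carbon-only groups.

From the compounds shown here alone, whether the oxygen itself matters remains open: a hydroxyl, an amine, a chlorine atom or a longer chain such as propyl at this position would show how far the order seen so far extends. Going by these compounds, it also remains open whether methyl, ethyl and methoxy keep the same order when the two chlorine atoms elsewhere on the shared core are replaced by other groups.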